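Lipophilicity notes on the shared quinolone core

This account rests on a few compounds, and the source may have more. Where it says the series, first, only, none or still open, it means among the compounds named here.

Measured so far, in a physicochemical assay for lipophilicity, at pH 7.4; on this read-out lower numbers stand for lower lipophilicity and higher numbers for higher lipophilicity:
compound 1, `CCc1c(C)[nH]c2cc(OC)c(Cl)cc2c1=O` — 2.43
compound 2, `COc1cc2[nH]c(C)c(C(C)C)c(=O)c2cc1Cl` — 2.84

Compound 2 stands highest of the two numbers; the nearest is compound 1, with a number 0.41 log units higher from compound 1 to compound 2 (beyond the scatter). Compound 3 is `CCCCC#Cc1c(C)[nH]c2cc(OC)c(Cl)cc2c1=O`, not yet measured in this assay. Its change from compound 2 is hex-1-yn-1-yl in place of isopropyl on an aromatic carbon. For the measured compounds named here, only the step from compound 1 to compound 2 bears on it, and it adds carbon at the same aromatic carbon; the entering hex-1-yn-1-yl brings more heavy atoms than the isopropyl it replaces. An upward step beyond the scatter is therefore expected, a number 0.66 log units higher from compound 2 to compound 3 (beyond the scatter). Compound 3 is estimated at 3.5, expected between 3 and 4.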

Compound 3, distribution coefficient: 2.45
Compound 3: middle estimate off by 1.05 log units, on the high side, outside the stated range (below it).
By their numbers in this assay, from the lowest: compounds 1 and 3 (each within the scatter of the next); then compound 2.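

At this aromatic carbon, in this assay, more heavy atoms do not go with a higher number: hex-1-yn-1-yl in place of isopropyl gives a number 0.39 log units lower from compound 2 to compound 3 (beyond the scatter) and hex-1-yn-1-yl in place of ethyl gives a number 0.02 log units higher from compound 1 to compound 3 (within the scatter) across the same position. The upward step from ethyl to isopropyl therefore does not carry over to this longer chain with its triple bond, and carbon count alone does not order the three compounds. Nothing measured here gives a reason for this result.

Open, on these data alone, is whether the triple bond or the chain length goes with the lower number, which a saturated hexyl chain at this carbon would separate. Also open, as far as these compounds go, is how an amine or a carboxylic acid at this position would read.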